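Substitution at the chain carbon on the aromatic nitrogen

The compounds below may be only part of what the source reports. "The series", "measured", "known", "first", "only" and "open" are said of these compounds alone.

Within the data shown here, compound 1 `Cn1c(Cc2nn(C)c(=O)c3ccccc23)nnc1SCCCCCCCC(=O)Nc1ccc(Cl)cc1Cl` gives 190 nM in an assay on NK92 cells for inhibition of interleukin-15 (Homo sapiens), read by AlphaScreen, with stated times of 30 min and 1 h (on this read-out higher numbers stand for weaker inhibition and lower numbers for stronger inhibition), and this is the only number the series holds so far. Compound 2 `Cn1nc(Cc2nnc(SCCCCCCCC(=O)Nc3ccc(Cl)cc3Cl)n2CCCO[Si](C)(C)C(C)(C)C)c2ccccc2c1=O` returns only a limit in this assay, > 30000 nM. The change an at least 150-fold higher number from compound 1 to compound 2 (2.19 log units; beyond the scatter) is a large loss. Compound 2 sits at the limit of > 30000 nM in this assay, at which 1 of the 2 values shown sits.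

Compound 3 `Cn1c(Cc2nn(CCC(=O)O)c(=O)c3ccccc23)nnc1SCCCCCCCC(=O)Nc1ccc(Cl)cc1Cl` differs from compound 1 by carboxymethyl in place of hydrogen on a saturated chain carbon bound to an aromatic nitrogen; cut one bond further out, the same difference reads methyl to 2-carboxyethyl. Among the measured compounds shown here, the one measured step at this place is the one from compound 1 to compound 2, and it was large, but the group that entered there was far bigger than the carboxymethyl that enters here. Compound 3 is therefore expected to lose activity in this assay, by a step of a 5.3-fold higher number from compound 1 to compound 3 (0.72 log units; beyond the scatter) that is estimated to be smaller than the measured one. Compound 3 is expected to give about 1000 nM in this assay, with a likely range from 200 nM to 10000 nM.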

Compound 3, half-maximal inhibitory concentration: > 30000 nM
Compound 3 ended at the assay's limit; the forecaster's own chance of this, stated with the estimate: 15%; middle value at least 30-fold (1.47 log units) away from the limit.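

Working notes: in this assay, carboxymethyl in place of hydrogen on a saturated chain carbon bound to an aromatic nitrogen gives an at least 150-fold higher number from compound 1 to compound 3 (2.19 log units; beyond the scatter). Among these compounds, this group is smaller than the one that enters in compound 2, and it sits on the other nitrogen-bound methyl of compound 1, so a large loss at this second place does not need a group of the size seen in compound 2. Compound 3 gives > 30000 nM, which is a limit of the assay and not a number, and it adds to the compounds at that ceiling: the limit of > 30000 nM in this assay, at which 2 of the 3 values shown sit.

The compounds shown leave open whether the loss at this place belongs to the carboxylic acid or to the chain that carries it, and a plain ethyl, a propyl chain, a 2-hydroxyethyl or the methyl ester of the acid would separate the two. From the compounds shown here alone, the full size of the step also stays unknown, and an amine on the same chain could show whether any group larger than methyl is accepted here.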